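Methoxy transfer onto a dichlorophenyl triarylethylene

A few compounds are considered here, and "the series" means these few. Any claim that something is new, unique, unknown or untested is made for them only; others in the source may bear on it.

Compound 1 `CC/C(=C(\c1ccccc1)c1ccc(NC(=O)C(C)C)cc1)c1ccc(OCc2ccccc2)cc1` and compound 2 `CC/C(=C(/c1ccc(NC(=O)C(C)C)cc1)c1ccc(OC)cc1)c1ccc(OCc2ccccc2)cc1` share one core. In a functional assay on HeLa cells (Homo sapiens) for inhibition, read by trypan blue exclusion, with a stated time of 72 h (on this read-out lower numbers stand for stronger inhibition of growth and higher numbers for weaker inhibition of growth), compound 1 gives 10200 nM, while compound 2 gives 4200 nM. The change between them is methoxy in place of hydrogen on an aromatic carbon, and it produced a 2.4-fold lower number from compound 1 to compound 2 (0.39 log units; beyond the scatter).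

Compound 3 `CC/C(=C(\c1ccccc1)c1ccc(NC(=O)C(C)C)cc1)c1ccc(Cl)cc1Cl` carries a different core; how it differs from compound 1 is not broken down here. In this assay compound 3 gives 3300 nM, which sits within the scatter of compound 2 and beyond the scatter from compound 1.

Compound 4 `CC/C(=C(/c1ccc(NC(=O)C(C)C)cc1)c1ccc(OC)cc1)c1ccc(Cl)cc1Cl` is not yet measured. It differs from compound 3 by methoxy in place of hydrogen on an aromatic carbon, the same change that was made from compound 1 to compound 2, with the place described in identical terms. On the expectation that this change carries over to the second core, the step from compound 3 to compound 4 is estimated at a 2.4-fold lower number from compound 3 to compound 4 (0.37 log units; beyond the scatter), a size resting on a 2.4-fold lower number from compound 1 to compound 2 (0.39 log units; beyond the scatter). Accordingly compound 4 is expected to give 1400 nM in this assay, with the estimate spanning 600 nM to 3500 nM.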

Compound 4, concentration for 50% growth inhibition: 2200 nM
Beside the measured number, compound 4's estimate is 1.6-fold (0.20 log units) below it; the range from low to high includes it.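

In this assay, methoxy in place of hydrogen on an aromatic carbon gave a 1.5-fold lower number from compound 3 to compound 4 (0.18 log units; within the scatter), a step that on this core cannot be told apart from no change at all. Set beside each other, the steps on the two cores do not differ by more than repeated measurements would allow: the same change on two cores in this assay, a 2.4-fold lower number (0.39 log units; beyond the scatter) from compound 1 to compound 2 and a 1.5-fold lower number (0.18 log units; within the scatter) from compound 3 to compound 4, 1.6-fold (0.21 log units) apart, within the scatter of two such steps. This agrees with the change carrying over from one core to the other, but it does not show that it does: one step stands beyond the scatter and the other within it, and two cores are too few to support a rule for the series.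

The compounds shown leave open whether a group other than methoxy at that place, such as a hydroxyl, an ethoxy or a fluorine, would give matching steps on the two cores. They also leave open whether the methoxy step would hold on a further core, for instance one carrying an amine or a carboxylic acid.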